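The compounds below may be only part of what the source reports. "The series", "measured", "known", "first", "only" and "open" are said of these compounds alone.

Going by the values given here, in a functional assay on MCF7 cells (Homo sapiens) for inhibition, read by fluorescence, with a stated time of 72 h (on this read-out higher numbers stand for weaker inhibition and lower numbers for stronger inhibition), two compounds with the same core have numbers so far. Compound 1 `CC(C)[C@H](N)COc1nc(NC(=N)N)c2ncn(C(C)C)c2n1` gives 3400 nM in this test, and compound 2 `CC(C)[C@@H](CO)Nc1nc(NC(=N)N)c2ncn(C(C)C)c2n1` gives 2100 nM in the same test. These two values lie within the usual scatter of each other, so compound 2 stands level with compound 1 and neither can be ranked above the other.

The next structure is compound 3 `CC(C)n1cnc2c(NC(=N)N)nc(N3CCC[C@H]3CO)nc21`, which keeps the core and changes one group: 2-(hydroxymethyl)pyrrolidin-1-yl in place of (1-(hydroxymethyl)-2-methylpropyl)amino on an aromatic carbon describes the swap. Among the compounds with values here, the place is an aromatic carbon between two ring nitrogen atoms, the same carbon that changed in the one measured step. Within the data shown here, that step is a 1.6-fold lower number from compound 1 to compound 2 (0.21 log units; within the scatter) and offers the only guide here. It involved a different pair of groups, and neither measured compound has a ring on this carbon, so the guide is thin. With that in mind, no step beyond the scatter is expected in this assay for this swap. The estimated step is a 1.2-fold higher number from compound 2 to compound 3 (0.08 log units; within the scatter) and carries wide uncertainty. Compound 3 is expected at 2500 nM with an estimated range from 900 nM to 7000 nM in this test.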

Compound 3, half-maximal inhibitory concentration: 6200 nM
Beside the measured number, compound 3's estimate is 2.5-fold (0.39 log units) below it, within the range that was stated.
By their numbers in this assay, from the lowest: compounds 2, 1 and 3 (each within the scatter of the next, the first and the last beyond it).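

In this assay, the aromatic carbon between two ring nitrogen atoms now shows its first step beyond the scatter: a 3.0-fold higher number from compound 2 to compound 3 (0.47 log units; beyond the scatter), modest in size, when 2-(hydroxymethyl)pyrrolidin-1-yl replaces (1-(hydroxymethyl)-2-methylpropyl)amino. Both groups hold 7 heavy atoms of the same elements, so the number at this position can shift without any change in that count, although the entering group differs in having a five-membered ring and 1 hydrogen-bond donor rather than 2. Measured against the 2-amino-3-methylbutoxy group, the change is a 1.8-fold higher number from compound 1 to compound 3 (0.26 log units; within the scatter), so compound 3 cannot be told apart from compound 1, and no measurement shown here explains the step from compound 2.

The compounds shown leave open whether the step goes with the ring itself or with the hydrogen-bond donor on the nitrogen attached to the aromatic carbon, as the two differences arrive together in compound 3. An open-chain tertiary amine carrying the same hydroxymethyl, or a piperidin-1-yl ring in place of the pyrrolidine, would help to pull these apart.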